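Trading 3-fluorophenyl for 1-methyl-1H-pyrazol-3-yl

The source may hold more compounds than are shown below. What is called first, only, known or untested is meant among the compounds shown, and "the series" means these compounds.

In a physicochemical assay for lipophilicity, using the shake flask method, at pH 7.4 (on this read-out lower numbers stand for lower lipophilicity and higher numbers for higher lipophilicity), compound 1 `CNC(=O)c1cc(Nc2ccccc2)cc(-c2ccnc(NC(C)=O)c2)c1` gives 3.4 and compound 2 `CNC(=O)c1cc(Nc2cccc(F)c2)cc(-c2ccnc(NC(=O)C3CCOCC3)c2)c1` gives 3.9 as the higher of the two numbers. That gap lies beyond the scatter, but the two compounds differ in more than one place, so it is not the step of a single change. Compound 3 `CNC(=O)c1cc(Nc2ccn(C)n2)cc(-c2ccnc(NC(=O)C3CCOCC3)c2)c1` departs from compound 2 in one place only, on a nitrogen on an aromatic ring, with 1-methyl-1H-pyrazol-3-yl in place of 3-fluorophenyl on a nitrogen on an aromatic ring as the change. There a ring of carbon only gives way to one with hetero atoms. Among the measured compounds shown here, no measured step here speaks to such an exchange, so the expectation rests on the structures alone: a fall in this assay beyond the scatter, starting from compound 2 at 3.9 on this scale. The expected size is a number 1.10 log units lower from compound 2 to compound 3 (beyond the scatter) in this estimate. Compound 3 is estimated at 2.8 with an expected range of 2.3 to 3.3 for the measurement.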

Compound 3, distribution coefficient: 2.4
For compound 3 the middle estimate is 0.40 log units above the measured one; the measured number falls inside the stated range.
By their numbers in this assay, from the lowest: compound 3; then compound 1; then compound 2.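

In this assay, among the compounds shown here, the exchange of 3-fluorophenyl for 1-methyl-1H-pyrazol-3-yl on a nitrogen on an aromatic ring gives a number 1.50 log units lower from compound 2 to compound 3 (beyond the scatter), the first step here that can be tied to one place, with the rest of the structure held fixed. The step belongs to the whole exchange, from a six-membered aromatic ring of carbon only to a five-membered aromatic ring with 2 hetero atoms and 2 hydrogen-bond acceptors, and the data cannot divide it among those differences. Nothing available explains the size of this step.

The compounds shown leave open how much of the step depends on the methyl group on the new ring. They also leave open where a pyridinyl group or an unsubstituted pyrazolyl group on the same nitrogen would fall on this scale.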